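The source may report more compounds than this note shows. Statements on the series, on what has been measured and on what is new or still open speak of the compounds shown alone.

Dichloroacetamides bearing an aryl group on the anilide ring. Compound 1 `CSc1ccc(-c2cc(NC(=O)C(Cl)Cl)cc(-c3ccc(SC)cc3)c2)cc1` in a functional assay on KB 3-1 cells (Homo sapiens) for cytotoxicity, read by MTT assay, with a stated time of 68 h (a lower number here means a stronger inhibitor, a higher number a weaker inhibitor), gives > 30000 nM, which is a limit of the assay rather than a number. Compound 2 `O=C(Nc1cccc(-c2cccs2)c1)C(Cl)Cl` in this assay gives > 50000 nM, again a limit and not a number. Compound 2 therefore stands at the limit of > 50000 nM in this assay, at which 1 of the 2 values shown sits. Going by the values given here, the only other value shown, from compound 1, sits at the limit of > 30000 nM in this assay, at which 1 of the 2 values shown sits. Compound 3 `O=C(Nc1cccc(-c2ccccc2)c1)C(Cl)Cl` differs from compound 2 by phenyl in place of thiophen-2-yl on an aromatic carbon. Among the compounds with values here, no measured step covers such a change here. No shift beyond the scatter is expected, and the estimate corresponds to a step that the limit leaves unreadable from compound 2 to compound 3. Compound 3 is expected at 60000 nM, within 20000 nM to 150000 nM, most likely reported again only as a limit.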

Compound 3, half-maximal inhibitory concentration: 46800 nM
For compound 3 the middle estimate is 1.3-fold (0.11 log units) above the measured one; measured number inside the range.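

With phenyl in place of thiophen-2-yl, compound 3 gives 46800 nM in this assay and is the only compound shown with a number and not a limit. The change reads as an at least 1.0-fold lower number from compound 2 to compound 3 (0.02 log units; that floor lies within the scatter) and so fixes only a floor. Compound 2 is held at a limit of the assay, and because of this the step has no upper bound: the limit of > 50000 nM in this assay, at which 1 of the 3 values shown sits.

As far as these compounds go, whether the true gap between thiophen-2-yl and phenyl exceeds the scatter stays open. Also open, from the compounds shown here alone, is how an amine or a carboxylic acid on this aromatic carbon would read in this assay.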